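The source may report more compounds than this note shows. Statements on the series, on what has been measured and on what is new or still open speak of the compounds shown alone.

Among the measured compounds shown here, in an ADME assay on microsomes from liver (Mus musculus) for metabolic stability, with a stated time of 10 min, tested at 0.5 uM (a higher number here means that more of the compound is left, a lower number that less of the compound is left), two compounds built on a shared core have numbers so far: compound 1 `COc1ncc(NC(=O)[C@H](C)[C@H]2CC[C@@H](c3ccnc4ccc(F)cc43)CC2)cn1` gives 51%, and compound 2 `C[C@@H](NC(=O)Nc1ccc(Cl)cc1)[C@H]1CC[C@@H](c2ccnc3ccc(F)cc32)CC1` gives 14%. Compound 2 is therefore the lower of the two, and its gap to compound 1 lies beyond the scatter.

Compound 3 `C[C@@H](NC(=O)C1CCCCC1)[C@H]1CC[C@@H](c2ccnc3ccc(F)cc32)CC1` has not yet been measured. It differs from compound 2 in one place: cyclohexyl in place of (4-chlorophenyl)amino on a carbonyl carbon. In words, cyclohexyl stands in place of (4-chlorophenyl)amino on a carbonyl carbon, and one six-membered aromatic ring of carbon only gives way to one six-membered non-aromatic ring of carbon only.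

For the measured compounds named here, no two measured compounds differ in just one place, so the data do not show directly what this change does in this assay. Compound 2, at 14%, has more room to rise than to fall on this read-out. The expected change is a number 6 percentage points higher from compound 2 to compound 3 (within the scatter), a small rise estimated to stay within the scatter. The estimate for compound 3 is 20%, with an expected range from 6% to 42%.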

Compound 3, percent of the compound remaining: 5%
Compound 3: the middle estimate sits 15 percentage points above what was measured; measured number outside the range, below it.
By their numbers in this assay, from the lowest: compounds 3 and 2 (each within the scatter of the next); then compound 1.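

Among the compounds shown here, this is the first direct reading at this position: in this assay, the single change on a carbonyl carbon gives a number 9 percentage points lower from compound 2 to compound 3 (within the scatter). One six-membered aromatic ring of carbon only thus gives way to one six-membered non-aromatic ring of carbon only, and the hydrogen-bond donor of the leaving group goes with it, yet the percent of compound remaining shows no change beyond the scatter, and the rise that had seemed possible from this swap does not appear. No measurement is available that would explain this result.

The step changes the ring and removes the amino nitrogen together, so the compounds shown cannot separate the contribution of either part, nor that of the chlorine on the leaving ring. On these data alone, it also remains open how the percent of compound remaining would respond if a different group stood on this carbonyl carbon, such as a morpholin-4-yl ring, a methoxy group or a short chain such as ethyl.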